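Compound 3 to compound 4: replacing the 2,6-dimethylphenyl group

The compounds below may be only part of what the source reports. "The series", "measured", "known", "first", "only" and "open" are said of these compounds alone.

Measured so far in an ADME assay on microsomes from liver (Homo sapiens) for metabolic stability, with a stated time of 10 min; a lower number here means that less of the compound is left, a higher number that more of the compound is left
- compound 1 `CC(=O)N1CC[C@@H](C(=O)N2CC[C@](c3ccc(C(OCc4c(F)cccc4F)(C(F)(F)F)C(F)(F)F)cc3)(S(=O)(=O)c3ccc(F)cc3)C2)C1` gives 9%
- compound 2 `O=C(O)C1CCN(C(=O)N2CC[C@](c3ccc(C(OCc4c(F)cccc4F)(C(F)(F)F)C(F)(F)F)cc3)(S(=O)(=O)c3ccc(F)cc3)C2)CC1` gives 72%
- compound 3 `Cc1cccc(C)c1COC(c1ccc([C@]2(S(=O)(=O)c3ccc(F)cc3)CCN(C(=O)[C@H]3CC[C@H](C(=O)O)CC3)C2)cc1)(C(F)(F)F)C(F)(F)F` gives 89%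

Compound 3 has the highest of the three numbers, beyond the scatter from both compound 2 and compound 1. The next compound, compound 4 `O=C(O)[C@H]1CC[C@H](C(=O)N2CC[C@](c3ccc(C(OCC4CCCC4)(C(F)(F)F)C(F)(F)F)cc3)(S(=O)(=O)c3ccc(F)cc3)C2)CC1`, keeps the carboxylic acid of compound 3 and differs as follows: cyclopentyl in place of 2,6-dimethylphenyl on a saturated chain carbon bound to an oxygen on a saturated carbon. The same difference reads 2,6-dimethylbenzyl to cyclopentylmethyl.

Within the data shown here, the only measured step is a number 63 percentage points higher from compound 1 to compound 2 (beyond the scatter). It is large, but it concerns a different group on a carbonyl carbon, so it says nothing directly about this change. Among the measured compounds shown here, no measured pair isolates the exchanged group. The expectation therefore rests on the two carboxylic acids, compound 2 at 72% and compound 3 at 89%, and a modest fall is expected rather than a collapse. The expected step is a number 9 percentage points lower from compound 3 to compound 4 (within the scatter). Compound 4 is estimated at 80%, with an expected range from 60% to 94%.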

Compound 4, percent of the compound remaining: 73%
The estimate for compound 4 lay 7 percentage points above the measured number, and the stated range covers the measured number.
By their numbers in this assay, from the lowest: compound 1; then compounds 2 and 4 (each within the scatter of the next); then compound 3.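

In this assay, among these compounds, this is the first exchange isolated on the saturated chain carbon bound to an oxygen on a saturated carbon, and a number 16 percentage points lower from compound 3 to compound 4 (beyond the scatter) shows that the number responds to the group at this position. The aromatic 2,6-dimethylphenyl can be exchanged for non-aromatic cyclopentyl, which has fewer heavy atoms, and compound 4 still gives 73%. No measurement shown here accounts for the size of this step.

On these data alone, it remains open whether a cyclohexyl ring, a pyridine ring or an open butyl chain at the same place would give a number like that of the 2,6-dimethylphenyl or the cyclopentyl compound. As far as these compounds go, it is also open whether the same exchange would give a similar step with the 4-carboxypiperidin-1-yl group on the carbonyl carbon.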